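Replacing the chloro substituent in an oxazole ketone series

The source may hold more compounds than are shown below. What is called first, only, known or untested is meant among the compounds shown, and "the series" means these compounds.

Compound 3 `O=C(CCCCCCc1ccccc1)c1ncc(Cl)o1` gives 5 nM in an assay (Rattus norvegicus) for inhibition of Fatty-acid amide hydrolase 1 (Homo sapiens) (on this read-out lower numbers stand for stronger inhibition and higher numbers for weaker inhibition), the second highest of three numbers: compound 2 `Cc1ccc(-c2cnc(C(=O)CCCCCCc3ccccc3)o2)nc1` gives 2.8 nM, and a 1.8-fold higher number from compound 2 to compound 3 (0.25 log units; within the scatter); compound 1 `COc1ccc(-c2cnc(C(=O)CCCCCCc3ccccc3)o2)cc1` gives 100 nM, and a 20-fold lower number from compound 1 to compound 3 (1.30 log units; beyond the scatter). Compound 4 `O=C(CCCCCCc1ccccc1)c1ncc(-c2cc(=O)[nH]c(=O)[nH]2)o1` carries a group of 8 heavy atoms (4 carbon, 2 nitrogen, 2 oxygen; one six-membered aromatic ring with 2 hetero atoms) in place of one chlorine atom, on an aromatic carbon. The two steps that exchange a ring at this carbon for chloro bear on it: a 20-fold lower number from compound 1 to compound 3 (1.30 log units; beyond the scatter) was large, while a 1.8-fold higher number from compound 2 to compound 3 (0.25 log units; within the scatter) stayed within the scatter, so a ring at this position can leave the number anywhere across that span. The new ring resembles neither precedent, so a modest rise in this assay is expected for compound 4, with wide uncertainty, a 4.0-fold higher number from compound 3 to compound 4 (0.60 log units; beyond the scatter). Compound 4 is therefore estimated at 20 nM, within 3 nM to 150 nM.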

Compound 4, inhibition constant: 12 nM
For compound 4 the middle estimate is 1.7-fold (0.22 log units) above the measured one; the range from low to high includes it.
By their numbers in this assay, from the lowest: compounds 2 and 3 (each within the scatter of the next); then compound 4; then compound 1.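

Compound 4 shows that this carbon accepts a ring with hydrogen-bond donors, although a 2.4-fold higher number from compound 3 to compound 4 (0.38 log units; beyond the scatter) is a modest rise over chloro. Among the rings, the new one falls between the earlier two, with a 4.3-fold higher number from compound 2 to compound 4 (0.63 log units; beyond the scatter) on one side and an 8.3-fold lower number from compound 1 to compound 4 (0.92 log units; beyond the scatter) on the other, so the ring's identity still moves the number beyond the scatter. No data given here explain this order among the three rings. Going by these compounds, whether a simple amine, a carboxylic acid or a morpholine ring at this carbon would stay near chloro remains open.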